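The source may hold more compounds than are shown below. What is called first, only, known or untested is meant among the compounds shown, and "the series" means these compounds.

Measured in a toxicity assay on RAW264.7 cells (Mus musculus) for cytotoxicity, read by MTT assay, with a stated time of 24 h; on this read-out lower numbers stand for stronger inhibition and higher numbers for weaker inhibition:

- compound 1 `C=C[C@@](C)(/C=C/c1ccc(OCc2cn(-c3ccc(C)cc3)nn2)cc1)CCC=C(C)C`, giving 86900 nM
- compound 2 `C=C[C@@](C)(/C=C/c1ccc(OCc2cn(-c3ccc(OC)cc3)nn2)cc1)CCC=C(C)C`, giving 47400 nM
- compound 3 `C=C[C@@](C)(/C=C/c1ccc(OC(=O)c2cn(-c3ccc(C)cc3)nn2)cc1)CCC=C(C)C`, giving 37200 nM

Compound 4 `C=C[C@@](C)(/C=C/c1ccc(OC(=O)c2cn(-c3ccc(OC)cc3)nn2)cc1)CCC=C(C)C` is not yet measured.

Compound 1 and compound 2 share a core and differ by methoxy in place of methyl on an aromatic carbon. In this assay this change gave a 1.8-fold lower number from compound 1 to compound 2 (0.26 log units; within the scatter), a step that stays within the scatter of repeated measurements.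

Compound 3 and compound 4 differ by methoxy in place of methyl on an aromatic carbon. The place of the change is described in the same words for both pairs, so this is the same change made on a second core. The difference between the core of compound 1 and the core of compound 3 is not broken down here. Among the three measured compounds, the number for compound 3 lies within the scatter of that of compound 2 and beyond the scatter of that of compound 1.

Going by the values given here, for compound 4, the only guide is the single earlier occurrence of the change. On that basis, a step of a 1.5-fold lower number from compound 3 to compound 4 (0.17 log units; within the scatter) is expected from compound 3 to compound 4 in this assay, since the same change gave a 1.8-fold lower number from compound 1 to compound 2 (0.26 log units; within the scatter). A single prior step, itself within the scatter, is a thin basis, so the expected range is wide. The number for compound 4 in this assay is estimated at 25000 nM, with a likely span from 12000 nM to 55000 nM.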

Compound 4, half-maximal inhibitory concentration: 64700 nM
Compound 4: middle estimate off by 2.6-fold (0.41 log units), on the low side; measured number outside the range, above it.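

In this assay, methoxy in place of methyl on an aromatic carbon gave a 1.7-fold higher number from compound 3 to compound 4 (0.24 log units; within the scatter), and the two occurrences of this change on different cores do not agree: the same change on two cores in this assay, a 1.8-fold lower number (0.26 log units; within the scatter) from compound 1 to compound 2 and a 1.7-fold higher number (0.24 log units; within the scatter) from compound 3 to compound 4, 3.2-fold (0.50 log units) apart, beyond the scatter of two such steps. The step seen on the core of compound 1 therefore did not carry over to the core of compound 3, and on this evidence a step measured on one of these cores is a poor guide to the same change on the other. This does not establish a dependable reversal, nor does it give a reason for the gap: each step alone stays within the scatter, only the gap between them lies beyond it, and the comparison rests on just two pairs of compounds.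

The compounds shown leave open which part of the difference between the two cores goes with the gap, and whether it would appear again with a third core. They also leave open how either core responds when an amine, a carboxylic acid or a longer chain such as ethoxy stands on the same aromatic carbon in place of methyl or methoxy.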